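Carbamoyl in place of cyano on the fused ring

This account rests on a few compounds, and the source may have more. Where it says the series, first, only, none or still open, it means among the compounds named here.

Three compounds of the series have numbers. Compound 1 `COc1cc(C)ccc1N1CCN(CCCNc2ncccc2C(=O)N(C)C)CC1` gives 0.794 nM in a functional assay for antagonist activity at Alpha-1A adrenergic receptor (Oryctolagus cuniculus); a lower number here means tighter binding, a higher number weaker binding; compound 2 `COc1cc(F)ccc1N1CCN(CCCNc2c(C(=O)N(C)C)cnc3c(C)cccc23)CC1` gives 7.94 nM in this assay, and compound 3 `COc1cc(F)ccc1N1CCN(CCCNc2c(C(=O)N(C)C)cnc3c(C#N)cccc23)CC1` gives 1.26 nM. For the measured compounds named here, compound 3 thus stands second highest of the three: its gap to compound 1 lies within the scatter, while the one single-point step, a 6.3-fold lower number from compound 2 to compound 3 (0.80 log units; beyond the scatter), lies beyond it. Compound 4 `COc1cc(F)ccc1N1CCN(CCCNc2c(C(=O)N(C)C)cnc3c(C(N)=O)cccc23)CC1` carries carbamoyl in place of cyano on an aromatic carbon. Going by the values given here, no measured step exchanges a cyano for a carbamoyl; the step from compound 2 to compound 3 shows only that a change on that aromatic carbon moves the number modestly. For compound 4 a step of at most modest size in this assay is therefore expected, direction uncertain. Compound 4 is estimated at 2 nM (range 0.6 nM to 6.3 nM). The expected step is a 1.6-fold higher number from compound 3 to compound 4 (0.20 log units; within the scatter).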

Compound 4, dissociation constant: 0.501 nM
For compound 4 the middle estimate is 4.0-fold (0.60 log units) above the measured one; the measured number lies below the stated range.
By their numbers in this assay, from the lowest: compounds 4, 1 and 3 (each within the scatter of the next, the first and the last beyond it); then compound 2.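

On this aromatic carbon, carbamoyl in place of cyano gives a 2.5-fold lower number from compound 3 to compound 4 (0.40 log units; beyond the scatter) in this assay, so the position tolerates the larger group, which brings a hydrogen-bond donor that cyano lacks. Against methyl, carbamoyl gives a 16-fold lower number from compound 2 to compound 4 (1.20 log units; beyond the scatter), the only large step on this carbon, and across compounds 2, 3 and 4 each step from the one before lies beyond the scatter. Nothing available explains why the number falls.

On these data alone, it remains open whether the carbamoyl hydrogens matter, which an N,N-dimethylcarbamoyl group would test. A carboxylic acid or an aminomethyl group on this carbon also remains to be placed in this order.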